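A few compounds are considered here, and "the series" means these few. Any claim that something is new, unique, unknown or untested is made for them only; others in the source may bear on it.

In a functional assay on A549 cells (Homo sapiens) for cytotoxicity, read by MTT assay, with a stated time of 48 h (on this read-out higher numbers stand for weaker inhibition and lower numbers for stronger inhibition), compound 1 (`CN(C)CCCCCSC1=Nc2ccccc2C(CC(=O)NCc2ccccc2)N1c1ccc(-c2ccc(F)cc2)cc1`) gives 17600 nM, level with compound 2 (`O=C(CC1c2ccccc2N=C(SCCCCCN2CCCC2)N1c1ccc(-c2ccc(F)cc2)cc1)NCc1ccccc1`) at 17800 nM, while compound 3 (`O=C(CC1c2ccccc2N=C(SCCCCCN2CCCC2)N1c1ccccc1)NCc1ccc(F)cc1`) gives a higher number, 89900 nM. Compound 4 (`CN(C)CCCCCSC1=Nc2ccccc2C(CC(=O)NCc2ccccc2)N1c1ccccc1`) departs from compound 1 in one place: hydrogen in place of 4-fluorophenyl on an aromatic carbon. Going by the values given here, the one measured step, a 1.0-fold higher number from compound 1 to compound 2 (0.00 log units; within the scatter), concerns the amine rather than this group, so it offers no direct measure of the change. It does suggest that a fair guide, also lacking the 4-fluorophenyl but differing from compound 1 elsewhere too, is compound 3 with its 89900 nM. The expected step, toward weaker inhibition, is a 4.3-fold higher number from compound 1 to compound 4 (0.63 log units; beyond the scatter). Compound 4 is estimated at 75000 nM, with an expected range from 35000 nM to 150000 nM.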

Compound 4, half-maximal inhibitory concentration: 138000 nM
Beside the measured number, compound 4's estimate is 1.8-fold (0.26 log units) below it; low and high end bracket the measured number.
By their numbers in this assay, from the lowest: compounds 1 and 2 (each within the scatter of the next); then compounds 3 and 4 (each within the scatter of the next).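

In this assay, hydrogen in place of 4-fluorophenyl on the aromatic carbon gives a 7.8-fold higher number from compound 1 to compound 4 (0.89 log units; beyond the scatter), the first direct measure of this change, as the earlier step concerned only the amine. With the dimethylamino chain held constant, the 4-fluorophenyl thus goes with the stronger inhibition at this position. No evidence is available to explain this step. The compounds shown leave open whether a plain phenyl or a single fluorine at this place would keep the lower number, and whether the step is the same size with the pyrrolidin-1-yl chain.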